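A few compounds are considered here, and "the series" means these few. Any claim that something is new, unique, unknown or untested is made for them only; others in the source may bear on it.

In a physicochemical assay for solubility, in phosphate buffer, at pH 6.5 (a lower number here means a less soluble compound, a higher number a more soluble compound), compound 1, whose structure is `COc1ccc(C(=O)/C=C/c2ccc(OCCNc3ccnc4cc(Cl)ccc34)c(OC)c2)c(OC)c1`, gives 3.1 ug/mL. Compound 2, with the structure `COc1cc(/C=C/C(C)=O)ccc1OCc1cn(-c2ccnc3cc(Cl)ccc23)nn1`, gives 3.1 ug/mL in this assay, which at the digits shown is level with compound 1 and within the scatter of it. Compound 3, with the structure `COc1ccc(C(=O)/C=C/c2cc(CN3CCN(c4ccnc5cc(Cl)ccc45)CC3)c(O)c(OC)c2)c(OC)c1`, reaches only a limit of this assay, namely < 1.6 ug/mL, and this is a limit rather than a number; it matches (the limit of < 1.6 ug/mL in this assay, at which 1 of the 3 values shown sits).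

The compound now in question is compound 4, whose structure is `COc1ccc(C(=O)/C=C/c2ccc(OCc3cn(-c4ccnc5cc(Cl)ccc45)nn3)c(OC)c2)c(OC)c1`. Its difference from compound 2 is 2,4-dimethoxyphenyl in place of methyl on a carbonyl carbon. For the measured compounds named here, no step between two measured compounds of this kind is available, so the size of the change can only be guessed from the compounds above. The step from compound 2 to compound 4 is expected to lower solubility modestly, as a 1.9-fold lower number from compound 2 to compound 4 (0.29 log units; within the scatter), though it may stay within the scatter. Compound 4 is therefore estimated at 1.6 ug/mL, within a range from 0.5 ug/mL to 5 ug/mL.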

Compound 4, solubility: < 1.6 ug/mL
Compound 4: only a limit was reported (the forecaster's own chance of this, stated with the estimate: 40%); the middle value sits exactly at the limit.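

In this assay, for the compounds shown here, this is the first single change that can be read at this place, on a carbonyl carbon whose other neighbour is a double-bonded chain carbon: 2,4-dimethoxyphenyl in place of methyl gives an at least 1.9-fold lower number from compound 2 to compound 4 (0.28 log units; that floor lies within the scatter). Compound 4 gives < 1.6 ug/mL, which is a limit of the assay and not a number. The step therefore has only a floor, and the values shown now gather at that limit: the limit of < 1.6 ug/mL in this assay, at which 2 of the 4 values shown sit.

Going by these compounds alone, the true size of the step stays open, as does whether the whole 2,4-dimethoxyphenyl or only one of its methoxy groups matters to the read-out. Also open, going by these compounds, is whether a morpholine or a carboxylic acid, placed on the same carbonyl carbon instead of 2,4-dimethoxyphenyl, would give a number rather than a limit in this assay.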